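The source may hold more compounds than are shown below. What is called first, only, known or untested is meant among the compounds shown, and "the series" means these compounds.

Among the measured compounds shown here, compound 2 `CSc1ccc(CNc2nc([SeH])nc3ccccc23)cc1` holds the only firm number in an ADME assay on 184B5 cells (Homo sapiens) for cytotoxicity, read by MTT assay, with a stated time of 72 h (a higher number here means a weaker inhibitor of growth, a lower number a stronger inhibitor of growth), where compound 2 gives 86300 nM. For compound 1 `CCCCC[Se]c1nc(NCc2ccc(SC)cc2)c2ccccc2n1` the assay returns only a limit, > 100000 nM, at the limit of > 100000 nM in this assay, at which 1 of the 2 values shown sits. For the measured compounds named here, the sole measured step is an at least 1.1-fold lower number from compound 1 to compound 2 (0.06 log units; that floor lies within the scatter). Compound 3 `[SeH]c1nc(NCc2ccccc2)c2ccccc2n1` differs from compound 2 by hydrogen in place of methylsulfanyl on an aromatic carbon. Going by the values given here, because an at least 1.1-fold lower number from compound 1 to compound 2 (0.06 log units; that floor lies within the scatter) sits at its floor and is the only measured step available, no shift beyond the scatter is expected in this assay, the expected step being a 1.2-fold higher number from compound 2 to compound 3 (0.06 log units; within the scatter). Compound 3 is therefore estimated at about 100000 nM, between 40000 nM and 250000 nM.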

Compound 3, concentration for total growth inhibition: 63600 nM
Compound 3: middle estimate off by 1.6-fold (0.20 log units), on the high side, within the range that was stated.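

In this assay, among the compounds shown here, hydrogen in place of methylsulfanyl on an aromatic carbon, para to a large group, gives the first step between two firm numbers (a 1.4-fold lower number from compound 2 to compound 3 (0.13 log units; within the scatter)), whereas the earlier step had only a floor. At this position, then, losing both heavy atoms of methylsulfanyl produces no shift beyond the scatter in this cell line. No data shown here explain this result. Going by these compounds, whether an amine, a carboxylic acid or a longer chain on that carbon would shift the number beyond the scatter remains open.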